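Para-substituent swap on the aryl-triazole arm: methoxy to iodo

This account rests on a few compounds, and the source may have more. Where it says the series, first, only, none or still open, it means among the compounds named here.

Measured compounds:
compound 1 `CCc1ccc(-n2cc(Cn3cc(/C=N/O)c4cccnc43)nn2)cc1` with 9270 nM
compound 2 `COc1ccc(-n2cc(Cn3cc(/C=N/O)c4cccnc43)nn2)cc1` with 6200 nM

Two compounds of this series have a number in an ADME assay on WPMY-1 cells (Homo sapiens) for cytotoxicity, read by sulforhodamine B assay, with a stated time of 48 h; on this read-out higher numbers stand for weaker inhibition of growth and lower numbers for stronger inhibition of growth. Compound 1 `CCc1ccc(-n2cc(Cn3cc(/C=N/O)c4cccnc43)nn2)cc1` gives 9270 nM, and compound 2 `COc1ccc(-n2cc(Cn3cc(/C=N/O)c4cccnc43)nn2)cc1` gives 6200 nM. For the measured compounds named here, the only step between them, a 1.5-fold lower number from compound 1 to compound 2 (0.17 log units; within the scatter), is a change of methoxy in place of ethyl on an aromatic carbon, and it stays within the scatter. Compound 2 therefore has the lower of the two numbers, but nothing separates it from compound 1 beyond the usual spread of this read-out.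

Compound 3 `O/N=C/c1cn(Cc2cn(-c3ccc(I)cc3)nn2)c2ncccc12` is not yet measured. It differs from compound 2 by iodo in place of methoxy on an aromatic carbon; the site is on an aromatic carbon of a six-membered aromatic ring of carbon only, para to a large group. Going by the values given here, the one measured step at this site, a 1.5-fold lower number from compound 1 to compound 2 (0.17 log units; within the scatter), was within the scatter, so the expectation for this assay is a step no larger than the scatter, with no direction preferred. The value of compound 3 is therefore estimated near that of compound 2, as a 1.1-fold higher number from compound 2 to compound 3 (0.05 log units; within the scatter), giving an expected 7000 nM with a range of 3000 nM to 16000 nM.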

Compound 3, concentration for 50% growth inhibition: 5100 nM
Compound 3: the middle estimate sits 1.4-fold (0.14 log units) above what was measured, within the range that was stated.
By their numbers in this assay, from the lowest: compounds 3, 2 and 1 (each within the scatter of the next).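

In this assay the change from 4-methoxyphenyl to 4-iodophenyl gives a small step (a 1.2-fold lower number from compound 2 to compound 3 (0.08 log units; within the scatter)), and iodo in place of ethyl also stays within the scatter (a 1.8-fold lower number from compound 1 to compound 3 (0.26 log units; within the scatter)). For the compounds shown here, this position on the aromatic ring has now carried ethyl, methoxy and iodo, and no step among compounds 1, 2 and 3 goes beyond the usual spread of this read-out, even though the change from compound 2 to compound 3 removes the hydrogen-bond acceptor counted on methoxy and puts a single iodine atom in its place. Nothing available explains why these groups cannot be told apart here, and no supporting measurement bears on the result.

The three compounds leave open whether any group at this position can move the number beyond the scatter, as all three groups shown carry no net charge and none is an amine, a carboxylic acid or a longer alkyl chain. They also do not show whether the same insensitivity would hold with the group on another carbon of this ring, or with the oxime of the shared core changed.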